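The compounds below may be only part of what the source reports. "The series", "measured", "known", "first", "only" and "open" are said of these compounds alone.

- compound 1 `N=C(N)c1ccc(/N=N/Nc2ccccc2C#Cc2ccccc2)cc1`: 8100 nM
- compound 2 `COc1ccc(C#Cc2cccc(N/N=N/c3ccc(C(=N)N)cc3)c2)cc1`: 5200 nM
- compound 3 `C#Cc1ccc(N/N=N/c2ccc(C(=N)N)cc2)cc1`: 11800 nM

These three compounds were tested in a functional assay on OVCAR-3 cells (Homo sapiens) for antiproliferative activity, read by WST assay, with a stated time of 72 h; a lower number here means a stronger inhibitor of growth, a higher number a weaker inhibitor of growth. In this assay compound 1 gives 8100 nM, which lies within the usual scatter of repeated measurements from both compound 2 at 5200 nM and compound 3 at 11800 nM. On these numbers, compound 1 cannot be separated from either neighbour.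

The next compound to be tested is compound 4 `N=C(N)c1ccc(/N=N/Nc2ccccc2C#Cc2ccc(F)cc2)cc1`. It differs from compound 1 in one place, with fluoro in place of hydrogen on an aromatic carbon, para to a large group (fluoro in place of hydrogen on an aromatic carbon). This turns the phenyl of the 2-phenylethynyl group into 4-fluorophenyl.

Within the data shown here, no pair of measured compounds differs in only one place, so the data show no direct precedent for this change. A shift beyond the scatter in this assay is therefore not expected, and neither direction is favoured. The expected change is small, a 1.2-fold lower number from compound 1 to compound 4 (0.06 log units; within the scatter). For compound 4 the estimated value is 7000 nM, with an expected range of 3000 nM to 16000 nM.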

Compound 4, concentration for 50% growth inhibition: 9500 nM
Estimate against measurement, compound 4: 1.4-fold (0.13 log units) below; the range from low to high includes it.
By their numbers in this assay, from the lowest: compounds 2, 1, 4 and 3 (each within the scatter of the next, the first and the last beyond it).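

In this assay the swap of hydrogen for fluoro on the 2-phenylethynyl group gives a 1.2-fold higher number from compound 1 to compound 4 (0.07 log units; within the scatter) and so provides the first direct reading of a single change among these compounds. At this position on the aromatic carbon para to a large group, phenyl and 4-fluorophenyl cannot be told apart on these numbers, so this one fluorine atom shows no clear gain or loss in growth inhibition. No measurement at hand offers an explanation for this result.

Going by these compounds, it remains open whether a different group on the same carbon, such as an amine or a carboxylic acid, would shift the number beyond the scatter. On these data alone, it is also open whether fluoro placed elsewhere on the core of compound 1 would behave in the same way.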